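Methyl added on the anilide ring of compound 3

The source may report more compounds than this note shows. Statements on the series, on what has been measured and on what is new or still open speak of the compounds shown alone.

Of the compounds shown here, three with the shared core have been measured in a functional assay on HEK293 cells for agonist activity at Glucose-dependent insulinotropic receptor (Homo sapiens), read by cAMP accumulation, with a stated time of 30 min; a lower number here means a smaller maximal response, a higher number a larger maximal response. Compound 1 `COc1cc2c(c(Oc3cccc(NS(=O)(=O)c4ccc(Cl)cc4)c3)n1)C(=O)N(C1CC1)C2=O` gives 97%, and compound 2 `Cc1cc2c(c(Oc3cccc(NS(=O)(=O)c4ccc(Cl)cc4)c3)n1)C(=O)N(C1CCCC1)C2=O` gives 95%. Compound 3 `Cc1cc2c(c(Sc3cccc(NS(=O)(=O)c4ccc(Cl)cc4)c3)n1)C(=O)N(C(C)C)C2=O` gives 76% in this assay and stands lowest of the three numbers; its nearest neighbour is compound 2, and the gap to it lies beyond the scatter, as does the larger gap to compound 1. No pair among these three differs in only one place, so none of the gaps can be tied to a single structural change.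

Compound 4 `Cc1cc2c(c(Sc3ccc(C)c(NS(=O)(=O)c4ccc(Cl)cc4)c3)n1)C(=O)N(C(C)C)C2=O` differs from compound 3 by the change (methyl in place of hydrogen on an aromatic carbon). Within the data shown here, no measured pair in this set shows such a change, so the size of its effect in this assay is not known from the data. The expectation is a small step, none beyond the scatter, in either direction, since the rest of the structure of compound 3 is kept. The estimate for compound 4 in this assay is 74%, with a range from 56% to 92%. This estimate means a step of a number 2 percentage points lower from compound 3 to compound 4 (within the scatter) and is expected to stay near the number of compound 3.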

Compound 4, largest response reached (reported as efficacy), in percent of the reference or control that the assay uses: 85%
The estimate for compound 4 lay 11 percentage points below the measured number, and the stated range covers the measured number.
By their numbers in this assay, from the lowest: compounds 3, 4, 2 and 1 (each within the scatter of the next, the first and the last beyond it).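

Among these compounds, the pair of compound 3 and compound 4 gives the first step that can be read at a single place: in this assay, methyl in place of hydrogen on the aromatic carbon ortho to the ((4-chlorophenyl)sulfonyl)amino group and para to a large group gives a number 9 percentage points higher from compound 3 to compound 4 (within the scatter). This position on the anilide ring therefore accepts a methyl without a change in maximal response that can be told from the scatter, so the added carbon neither gains nor costs anything measurable here. No supporting data bear on this step, and the pair gives its size alone.

On these data alone, whether the position accepts more than a methyl stays open; a methoxy, a chlorine atom, a dimethylamino group or a longer chain such as propyl at the same carbon would show how much room the response leaves there. As far as these compounds go, it is also open whether the same methyl gives a similar step on the ether-linked compounds, compound 1 and compound 2, whose numbers lie closer to the top of the series.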